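Sulfonamide Chaperone Inhibitors: From Fluorophenyl to Dichlorophenyl

The source may hold more compounds than are shown below. What is called first, only, known or untested is meant among the compounds shown, and "the series" means these compounds.

Measured so far:
compound 1, `O=S(=O)(Nc1ccc(-c2nc3ccccc3o2)cc1)c1cccc(F)c1`, 71000 nM
compound 2, `O=S(=O)(Nc1ccc2oc(-c3ccccc3)nc2c1)c1ccccc1O`, 85000 nM

Both compounds were tested in an assay on cells for inhibition of HSP60/HSP10 (Homo sapiens), with a stated time of 60 min; on this read-out higher numbers stand for weaker inhibition and lower numbers for stronger inhibition. Compound 1 gives 71000 nM, and compound 2 gives 85000 nM. Compound 1 has the lower of the two numbers, but its gap to compound 2 lies within the usual scatter, so the two cannot be told apart on these data; both are weak inhibitors.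

Compound 3, `O=S(=O)(Nc1ccc(-c2nc3ccccc3o2)cc1)c1ccc(Cl)c(Cl)c1`, has not yet been measured. It differs from compound 1 in one place: 3,4-dichlorophenyl in place of 3-fluorophenyl on a sulfonyl sulfur. Among the compounds with values here, no measured pair shows what such a swap does, so the expectation rests on compound 1 alone. The step of a 1.3-fold lower number from compound 1 to compound 3 (0.11 log units; within the scatter) is expected to stay within the scatter, with no clear direction. Compound 3 is therefore estimated at 55000 nM, with a range from 15000 nM to 150000 nM.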

Compound 3, half-maximal inhibitory concentration: 25000 nM
Estimate against measurement, compound 3: 2.2-fold (0.34 log units) above; the measured number falls inside the stated range.
By their numbers in this assay, from the lowest: compound 3; then compounds 1 and 2 (each within the scatter of the next).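

In this assay the group on the sulfonyl sulfur can move the number: 3,4-dichlorophenyl in place of 3-fluorophenyl gives a 2.8-fold lower number from compound 1 to compound 3 (0.45 log units; beyond the scatter) and the lower number means stronger inhibition. Within the data shown here, this is the first single change that can be read, as compound 1 and compound 2 sit within the scatter of each other and differ in more than one place. No measurement here explains why this swap lowers the number.

The swap removes fluorine and brings in two chlorines at once, so these compounds cannot tell whether the kind of halogen or the number of halogens carries the step. They also leave open how a phenyl ring bearing an amine or a carboxylic acid would behave on the sulfonyl sulfur.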